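A Methoxy for Trifluoromethyl Exchange in a Weak Series

This account rests on a few compounds, and the source may have more. Where it says the series, first, only, none or still open, it means among the compounds named here.

Compound 1 `CNC(=O)c1ccccc1Oc1nc(Nc2ccccc2OC)ncc1Br` gives > 50000 nM in a functional assay on MCF7 cells (Homo sapiens) for antiproliferative activity, read by MTT assay, with a stated time of 24 h (a lower number here means a stronger inhibitor, a higher number a weaker inhibitor), and this is a limit of the assay rather than a number.
Compound 2 `CNC(=O)c1ccccc1Oc1nc(Nc2cccc(C(F)(F)F)c2)ncc1Br` gives 57800 nM in this assay.

For the measured compounds named here, compound 2 therefore stands as the only measured number in this assay; the one other value shown, that of compound 1, is a limit, (the limit of > 50000 nM in this assay, at which 1 of the 2 values shown sits). Going by the values given here, no step between two measured compounds that differ in a single place is available here, so nothing in the measured data tells how far a single change can move this read-out.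

Compound 3 `CNC(=O)c1ccccc1Oc1nc(Nc2cccc(OC)c2)ncc1Br` differs from compound 2 in one place: methoxy in place of trifluoromethyl on an aromatic carbon, meta to a large group. With compound 2 already weak and compound 1 at a limit, the expectation for compound 3 is a step of essentially no size, nothing beyond the usual scatter, in either direction. Compound 3 is estimated at 60000 nM, within a range of 25000 nM to 150000 nM. That estimate corresponds to an expected step of a 1.0-fold higher number from compound 2 to compound 3 (0.02 log units; within the scatter).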

Compound 3, half-maximal inhibitory concentration: 18200 nM
Beside the measured number, compound 3's estimate is 3.3-fold (0.52 log units) above it; measured number outside the range, below it.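

In this assay, for the compounds shown here, the exchange gives the first single change that can be read, a 3.2-fold lower number from compound 2 to compound 3 (0.50 log units; beyond the scatter), so the read-out does respond to what sits on this aromatic carbon, meta to a large group, even though the numbers remain high. The second comparison, 3-methoxyphenyl in place of 2-methoxyphenyl on a nitrogen on an aromatic ring, gives an at least 2.7-fold lower number from compound 1 to compound 3 (0.43 log units; beyond the scatter), which shows that the place of the methoxy on this ring also counts. That second step is a bound and not a measured size, since compound 1 stands at a limit of the assay: the limit of > 50000 nM in this assay, at which 1 of the 3 values shown sits.

The compounds shown leave open whether the lower number belongs to methoxy itself or would also appear with other groups at this place, such as a hydroxyl, an amine or a carboxylic acid. They also leave open whether a longer chain on the oxygen, or a change elsewhere on the shared core, would move the number further.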